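This account rests on a few compounds, and the source may have more. Where it says the series, first, only, none or still open, it means among the compounds named here.

Measured compounds:
Compound 1 `CCCCOc1ccc(-c2c(C)[nH]c(=O)n2C)cc1`, giving 5100 nM in a functional assay on brain (Rattus norvegicus, strain Wistar) for inhibition; a higher number here means a weaker inhibitor, a lower number a stronger inhibitor.
Compound 2 `CCCCCCCCCCOc1ccc(-c2c(C)[nH]c(=O)n2C)cc1`, giving 6900 nM in this assay.
Compound 3 `CCCCCCCCCCCCCCc1ccc(-c2c(C)[nH]c(=O)n2C)cc1`, giving 43800 nM in this assay.

Compound 1 has the lowest number of the three. Compound 2 stands nearest to it, and the step of a 1.4-fold higher number from compound 1 to compound 2 (0.13 log units; within the scatter) lies within the scatter, so the two cannot be ordered. Compound 3 gives a number beyond the scatter above that of compound 1.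

Compound 4 `Cc1[nH]c(=O)n(C)c1-c1ccc(-c2ccccc2)cc1` has not yet been measured. It differs from compound 1 in one place: phenyl in place of butoxy on an aromatic carbon. For the measured compounds named here, none of the measured steps exchanges a chain for a ring at this position; the only measured step, from compound 1 to compound 2, lengthens the chain and stays within the scatter. Going by the values given here, with no direct precedent, the expected step of a 1.2-fold higher number from compound 1 to compound 4 (0.07 log units; within the scatter) is small, in no firm direction, and may well stay within the scatter. Compound 4 is therefore estimated at 6000 nM, in a range from 2000 nM to 20000 nM.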

Compound 4, half-maximal inhibitory concentration: 6300 nM
Beside the measured number, compound 4's estimate is 1.1-fold (0.02 log units) below it, within the range that was stated.
By their numbers in this assay, from the lowest: compounds 1, 4 and 2 (each within the scatter of the next); then compound 3.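

In this assay, phenyl in place of butoxy on this aromatic carbon gives a 1.2-fold higher number from compound 1 to compound 4 (0.09 log units; within the scatter) and so leaves the number within the scatter. The earlier compounds had shown this only for a change in chain length, whereas here the oxygen and the open chain both leave and a six-membered aromatic ring of carbon only enters, so this position accepts both a chain and a ring with no change that can be read. Nothing measured here accounts for the two groups reading alike.

Going by these compounds, it remains open whether an amine, a carboxylic acid or a saturated ring such as cyclohexyl on this carbon would stay within the scatter as well. Also open, on these data alone, is whether a substituted phenyl or any other group here could bring the number beyond the scatter below that of compound 1.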